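The source may hold more compounds than are shown below. What is called first, only, known or untested is meant among the compounds shown, and "the series" means these compounds.

Measured so far in a functional assay on HeLa cells (Homo sapiens) for antiproliferative activity, with a stated time of 24 h; a higher number here means a weaker inhibitor, a lower number a stronger inhibitor:
- compound 1, `NC(=O)c1c(NC(=O)c2ccc(C(F)(F)F)cc2)sc2c1CCN(Cc1c(Cl)cccc1Cl)C2`, gives > 50000 nM, which is a limit of the assay and not a number.
- compound 2, `Cc1ccc(C(=O)Nc2sc3c(c2C(N)=O)CCN(Cc2c(Cl)cccc2Cl)C3)cc1`, gives 47400 nM.
- compound 3, `NC(=O)c1c(NC(=O)c2ccc(C(F)(F)F)cc2)sc2c1CCN(C(=S)Nc1ccccc1Cl)C2`, gives 44000 nM.

Compound 1 and compound 2 share a core and differ only by methyl in place of trifluoromethyl on an aromatic carbon; that change gave an at least 1.0-fold lower number from compound 1 to compound 2 (0.02 log units; that floor lies within the scatter). The core of compound 3 differs from the core of compound 1 by a group of 10 heavy atoms (7 carbon, 1 nitrogen, 1 sulfur, 1 chlorine; one six-membered aromatic ring of carbon only) in place of a group of 9 heavy atoms (7 carbon, 2 chlorine; one six-membered aromatic ring of carbon only), on an amine nitrogen in a ring. Compound 4, `Cc1ccc(C(=O)Nc2sc3c(c2C(N)=O)CCN(C(=S)Nc2ccccc2Cl)C3)cc1`, has not been measured; it differs from compound 3 by methyl in place of trifluoromethyl on an aromatic carbon, the same change at the same place as between compound 1 and compound 2. Since that earlier step stayed within the scatter, the step from compound 3 to compound 4 is expected to be similar, about a 1.1-fold lower number from compound 3 to compound 4 (0.04 log units; within the scatter). On that basis compound 4 is estimated at 40000 nM, with a plausible range from 20000 nM to 80000 nM.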

Compound 4, half-maximal inhibitory concentration: 26300 nM
Beside the measured number, compound 4's estimate is 1.5-fold (0.18 log units) above it, and the stated range covers the measured number.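

In this assay, methyl in place of trifluoromethyl gives a 1.7-fold lower number from compound 3 to compound 4 (0.22 log units; within the scatter), and changing the group on the amine nitrogen in the ring gives a 1.8-fold lower number from compound 2 to compound 4 (0.26 log units; within the scatter), so neither step stands clear of repeat-measurement noise. Compound 1 carries a limit of the assay and not a number, so whether the methyl change carries over from one core to the other stays undecided: the same change on two cores in this assay, an at least 1.0-fold lower number (0.02 log units; that floor lies within the scatter) from compound 1 to compound 2 and a 1.7-fold lower number (0.22 log units; within the scatter) from compound 3 to compound 4; the limit leaves it open whether they differ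
The change on the ring nitrogen stays undecided in the same way: the same change on two cores in this assay, an at least 1.1-fold lower number (0.05 log units; that floor lies within the scatter) from compound 1 to compound 3 and a 1.8-fold lower number (0.26 log units; within the scatter) from compound 2 to compound 4; the limit leaves it open whether they differ

Still open, from the compounds shown here alone, is how a methoxy group or an amine on the same aromatic carbon would read in this assay. Also open, going by these compounds, is whether any such group would move the number beyond the scatter.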